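The source may hold more compounds than are shown below. What is called first, only, known or untested is meant among the compounds shown, and "the series" means these compounds.

Notes on the series. Compound 1 `C#CCNC1CCc2c(SCc3ccc(Cl)cc3)cccc21` gives 180 nM in an assay on cells for inhibition of Amine oxidase [flavin-containing] B (Homo sapiens), read by fluorescence and Amplex Red, with stated times of 30 min and 15 min; on this read-out higher numbers stand for weaker inhibition and lower numbers for stronger inhibition. Compound 2 `C#CCNC1CCc2c(OCCc3cc(NC(C)=O)ccc3Cl)cccc21` gives 590 nM in this assay. Compound 3 `C#CCNC1CCc2c(OCCc3cc(NC(=O)c4ccccc4)ccc3Cl)cccc21` gives only the limit > 20000 nM in this assay, not a number. For the measured compounds named here, the step of an at least 33-fold higher number from compound 2 to compound 3 (1.53 log units; beyond the scatter) places compound 3 at the limit of > 20000 nM in this assay, at which 1 of the 3 values shown sits, the one compound of the three that sits there. Compound 4 `C#CCNC1CCc2c(OCCc3cc(NC(=O)c4cccc(F)c4)ccc3Cl)cccc21` differs from compound 3 by fluoro in place of hydrogen on an aromatic carbon. Going by the values given here, no measured step touches this change; the only step in the set, an at least 33-fold higher number from compound 2 to compound 3 (1.53 log units; beyond the scatter), concerns a different change and is large. Given that compound 3 stands at the limit of > 20000 nM in this assay, at which 1 of the 3 values shown sits, the estimated step is a step that the limit leaves unreadable from compound 3 to compound 4, none beyond the scatter. Compound 4 is expected at 30000 nM, range 8000 nM to 100000 nM, and is likely to be reported again as a limit.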

Compound 4, half-maximal inhibitory concentration: > 20000 nM
Compound 4: a limit, no number (the forecaster's own chance of this, stated with the estimate: 80%); the middle value does not contradict the limit.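

In this assay compound 4 gives the limit > 20000 nM and no number. Fluoro in place of hydrogen on the aromatic carbon, meta to a large group, gives no measured value, and the step between the two limits of compound 3 and compound 4 cannot be read. The second aromatic amide shows an at least 33-fold higher number from compound 2 to compound 4 (1.53 log units; beyond the scatter) with 3-fluorophenyl in place of methyl on the carbonyl carbon, so the loss seen with phenyl recurs: the limit of > 20000 nM in this assay, at which 2 of the 4 values shown sit.

On these data alone, whether fluoro changes inhibition at all stays open. Also open, as far as these compounds go, is how an ethyl or a cyclopropyl on the carbonyl carbon would read.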